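Swapping Chlorines for Hydroxyls on the Aryl Ring

The compounds below may be only part of what the source reports. "The series", "measured", "known", "first", "only" and "open" are said of these compounds alone.

Of the compounds shown here, three share a core and have been tested in a functional assay on DU-145 cells (Homo sapiens) for inhibition, read by trypan blue exclusion, with a stated time of 96 h; on this read-out lower numbers stand for stronger inhibition of growth and higher numbers for weaker inhibition of growth. Compound 1 `O=C(/C(=C\c1c(O)cc(O)cc1O)SCc1ccc(Cl)cc1Cl)c1ccc(Cl)cc1` gives 25000 nM. Compound 2 `Cc1ccc(CS/C(=C/c2cc([N+](=O)[O-])ccc2F)C(=O)c2ccc(Cl)cc2)cc1` gives 1000 nM. Compound 3 `Cc1ccc(CS/C(=C/c2cc(Cl)cc(Cl)c2)C(=O)c2ccc(Cl)cc2)cc1` gives 10000 nM, the second highest of the three numbers, nearer to compound 1 than to compound 2. Within the data shown here, the one measured step, a 10-fold higher number from compound 2 to compound 3 (1.00 log units; beyond the scatter), shows that changing the group on this double-bonded chain carbon can move the number well beyond the scatter.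

Compound 4 `Cc1ccc(CS/C(=C/c2c(O)cc(O)cc2O)C(=O)c2ccc(Cl)cc2)cc1` differs from compound 3 in that place: 2,4,6-trihydroxyphenyl in place of 3,5-dichlorophenyl on a double-bonded chain carbon bound to a double-bonded chain carbon. Among the measured compounds shown here, no measured step covers this exact change, so the step from compound 2 to compound 3 bears on it only by showing that this position matters. Compound 1 also carries 2,4,6-trihydroxyphenyl, though with a different group on the sulfur, and its number is the highest of the three. On that basis the step from compound 3 to compound 4 is expected to be a 2.5-fold higher number from compound 3 to compound 4 (0.40 log units; beyond the scatter), toward weaker inhibition. Compound 4 is therefore estimated at 25000 nM, with a likely range from 8000 nM to 80000 nM.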

Compound 4, concentration for 50% growth inhibition: 50000 nM
Estimate against measurement, compound 4: 2.0-fold (0.30 log units) below; the measured number falls inside the stated range.
By their numbers in this assay, from the lowest: compound 2; then compound 3; then compounds 1 and 4 (each within the scatter of the next).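

In this assay this position now has a direct comparison: 2,4,6-trihydroxyphenyl in place of 3,5-dichlorophenyl gives a 5.0-fold higher number from compound 3 to compound 4 (0.70 log units; beyond the scatter) and moves toward weaker inhibition of growth. The same group in place of 2-fluoro-5-nitrophenyl gives a 50-fold higher number from compound 2 to compound 4 (1.70 log units; beyond the scatter) and moves the same way, a larger step. With the 2,4,6-trihydroxyphenyl group held fixed, 4-methylphenyl in place of 2,4-dichlorophenyl on a saturated chain carbon bound to a sulfur gives a 2.0-fold higher number from compound 1 to compound 4 (0.30 log units; within the scatter) and so cannot be told from repeat variation. No supporting data are available to explain these steps.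

Going by these compounds, an amine or a carboxylic acid on this aryl ring remains open, as does a ring carrying a single hydroxyl. Also open, on these data alone, is whether the swap on the sulfur side would stay this small with 2-fluoro-5-nitrophenyl in place.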